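From Chlorophenyl to Indolyl: Tolerance on Liver Cells

The source may hold more compounds than are shown below. What is called first, only, known or untested is meant among the compounds shown, and "the series" means these compounds.

Within the data shown here, only two compounds carry numbers so far. Compound 1 `NC(=S)Nc1cccc(OCCCCCCCCNC(=S)Nc2ccccc2Br)c1` gives 36000 nM in an ADME assay on Huh-7 cells (Homo sapiens) for cytotoxicity; a lower number here means that less compound is tolerated, a higher number that more compound is tolerated. Compound 2 `NC(=S)Nc1cccc(OCCCCCCCCNC(=S)Nc2ccc(Cl)cc2)c1` gives 18000 nM in this assay. Among the measured compounds shown here, the single step between them, a 2.0-fold lower number from compound 1 to compound 2 (0.30 log units; within the scatter), is the change 4-chlorophenyl in place of 2-bromophenyl on an amide-type nitrogen; it stays within the scatter, so compound 2 holds the lower of the two numbers without being separable from compound 1.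

Compound 3 `NC(=S)Nc1cccc(OCCCCCCCCNC(=S)Nc2ccc3[nH]ccc3c2)c1` is not yet measured. It differs from compound 2 by 1H-indol-5-yl in place of 4-chlorophenyl on an amide-type nitrogen; the group that leaves is a six-membered aromatic ring of carbon only with no hydrogen-bond donor, the one that enters carries a five-membered aromatic ring with one hetero atom and brings one hydrogen-bond donor. For the measured compounds named here, no measured step touches this kind of exchange; the only measured step swapped one halogenated phenyl for another and stayed within the scatter. On that slim basis compound 3 is expected to give 22000 nM in this assay, with a range from 9000 nM to 55000 nM. The step of a 1.2-fold higher number from compound 2 to compound 3 (0.09 log units; within the scatter) is therefore expected to stay within the scatter.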

Compound 3, half-maximal cytotoxic concentration: 18000 nM
Beside the measured number, compound 3's estimate is 1.2-fold (0.09 log units) above it; the measured number falls inside the stated range.
By their numbers in this assay, from the lowest: compounds 2, 3 and 1 (each within the scatter of the next).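

On the amide-type nitrogen whose other neighbour is the thiocarbonyl carbon, the exchange now reaches beyond halogenated phenyl groups, and in this assay it reads as no change at the digits printed from compound 2 to compound 3 (within the scatter), while the comparison with the bromine-bearing compound reads as a 2.0-fold lower number from compound 1 to compound 3 (0.30 log units; within the scatter). Until now, only one halogenated phenyl had been swapped for another; 1H-indol-5-yl removes the chlorine and adds a five-membered aromatic ring with 1 hetero atom and 1 hydrogen-bond donor, yet all three compounds remain inseparable in this read-out, so at this position the number tolerates a wider structural exchange than the first pair could show. Nothing available here accounts for this result.

These three compounds share the same core and chain and differ only in the aromatic group on this nitrogen, so they leave open whether any group placed there would produce a step beyond the scatter, such as a phenyl carrying a carboxylic acid or an amine. They also say nothing about how the number would respond to a change elsewhere in the molecule, such as a longer chain or the replacement of the thiocarbonyl sulfur by oxygen to give a carbonyl.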